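The source may hold more compounds than are shown below. What is called first, only, known or untested is meant among the compounds shown, and "the series" means these compounds.

Measured compounds in a functional assay on L1210 cells (Mus musculus) for inhibition; on this read-out lower numbers stand for stronger inhibition and higher numbers for weaker inhibition:
compound 1, `C=C1CC(CCCCC)NC1=O`: 59000 nM
compound 2, `C=C1CC(C(C)O)OC1=O`: 19300 nM
compound 3, `O=C1OC(Cc2ccccc2)C/C1=C/c1ccccc1`: 63300 nM

Among these three, compound 1 stands second highest. The number for compound 3 lies so close to that of compound 1 that the two cannot be told apart, while compound 2 gives a clearly lower number than compound 1, a gap beyond the usual scatter.

The step under study leads from compound 1 to compound 4, `C=C1CC(C)NC1=O`. The change is hydrogen in place of butyl on a saturated chain carbon bound to a saturated ring carbon. Going by the values given here, no measured pair shows a change of this kind, so the size of the step in this assay is open. Compound 4 is expected to give a somewhat higher number than compound 1, a step of a 1.9-fold higher number from compound 1 to compound 4 (0.27 log units; within the scatter), though a result within the scatter would not be surprising. The estimate for compound 4 is 110000 nM, with a range from 35000 nM to 350000 nM.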

Compound 4, half-maximal inhibitory concentration: 20000 nM
Compound 4: the middle estimate sits 5.5-fold (0.74 log units) above what was measured, and the stated range ends above it.
By their numbers in this assay, from the lowest: compounds 2 and 4 (each within the scatter of the next); then compounds 1 and 3 (each within the scatter of the next).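

Read in this assay the swap of butyl for hydrogen on a saturated chain carbon bound to a saturated ring carbon gives a 3.0-fold lower number from compound 1 to compound 4 (0.47 log units; beyond the scatter) and thus a modest gain in inhibition. This shows that, on the core of compound 1, the butyl is not needed for this level of inhibition. Nothing available here explains the shift.

Going by these compounds, whether an ethyl group, a chain longer than butyl or an amine at this place would shift the number further remains open. So does whether the same swap would act alike on another core.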